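Carboxy in place of fluoro on the aryl ring of compound 2

The source may report more compounds than this note shows. Statements on the series, on what has been measured and on what is new or still open speak of the compounds shown alone.

For the measured compounds named here, in an assay on microsomes for inhibition of acyl-CoA:cholesterol acyltransferase (Oryctolagus cuniculus) (on this read-out lower numbers stand for stronger inhibition and higher numbers for weaker inhibition), compound 2 `CC(C)c1cccc(C(C)C)c1NC(=O)NCC1(c2ccc(F)cc2)CCCC1` gives 23 nM, the lowest of the three numbers so far. Compound 3 `CC(C)c1cccc(C(C)C)c1NC(=O)NCC1(c2cccc(N(C)C)c2)CCCC1` gives 33 nM, and compound 1 `CC(C)c1ccc(C2(CNC(=O)Nc3c(C(C)C)cccc3C(C)C)CCCC2)cc1` gives 48 nM. Among the measured steps, a 2.1-fold lower number from compound 1 to compound 2 (0.32 log units; beyond the scatter) is the only one beyond the scatter; a 1.4-fold higher number from compound 2 to compound 3 (0.16 log units; within the scatter) and a 1.5-fold lower number from compound 1 to compound 3 (0.16 log units; within the scatter) stay within it. Compound 4 `CC(C)c1cccc(C(C)C)c1NC(=O)NCC1(c2ccc(C(=O)O)cc2)CCCC1` differs from compound 2 by carboxy in place of fluoro on an aromatic carbon. Going by the values given here, none of the measured steps brings in a carboxy group, so there is no direct precedent. The closest comparisons are the exchange of a substituent on the same aromatic ring, a 2.1-fold lower number from compound 1 to compound 2 (0.32 log units; beyond the scatter), and the exchange of the whole aryl group, a 1.4-fold higher number from compound 2 to compound 3 (0.16 log units; within the scatter), both small; the present change is larger in what enters than either. The step expected in this assay is a 3.9-fold higher number from compound 2 to compound 4 (0.59 log units; beyond the scatter), toward a higher number, and the uncertainty is wide. Compound 4 is estimated at 90 nM, with a range from 25 nM to 350 nM.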

Compound 4, half-maximal inhibitory concentration: 3100 nM
Compound 4: middle estimate off by 34-fold (1.54 log units), on the low side; the whole stated range lies below it.
By their numbers in this assay, from the lowest: compounds 2, 3 and 1 (each within the scatter of the next, the first and the last beyond it); then compound 4.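

In this assay the aromatic carbon para to a large group proves far from indifferent: carboxy in place of fluoro brings a 130-fold higher number from compound 2 to compound 4 (2.13 log units; beyond the scatter) at this position, and carboxy in place of isopropyl brings a 65-fold higher number from compound 1 to compound 4 (1.81 log units; beyond the scatter) at the same position, where fluoro and isopropyl had differed only modestly. The 4-carboxyphenyl group also stands well apart from the 3-(dimethylamino)phenyl group, with a 94-fold higher number from compound 3 to compound 4 (1.97 log units; beyond the scatter) in the same direction, so none of the earlier aryl groups comes near it.

On these data alone, whether the weaker inhibition belongs to the free carboxylic acid or would also follow a methyl ester, a primary amide or a hydroxymethyl group at this place stays open. So does whether a carboxy group carried on a longer chain would fare any better. Nothing available here speaks to the reason for this large step.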